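From amino to pyrrolidin-1-yl on compound 3

The compounds below may be only part of what the source reports. "The series", "measured", "known", "first", "only" and "open" are said of these compounds alone.

In a toxicity assay on CHO cells (Cricetulus griseus) for cytotoxicity, read by WST assay, with a stated time of 24 h (a higher number here means a weaker inhibitor, a lower number a stronger inhibitor), compound 1 (`CC(C)=CCCC(C)=CCNCCCN`) reaches only a limit, > 150000 nM. Compound 2 (`CC(C)=CCCC(C)=CCNCCCN(CCCN)CCCN`) gives 127000 nM, while compound 3 (`CC(C)=CCC/C(C)=C\CCC(C)=CCNCCCN`) gives 32100 nM, the lower of the two actual numbers. Compound 4 (`CC(C)=CCC/C(C)=C\CCC(C)=CCNCCCN1CCCC1`) carries pyrrolidin-1-yl in place of amino on a saturated chain carbon, three bonds along the chain from an amine nitrogen. Among the measured compounds shown here, the only measured step, an at least 4.6-fold lower number from compound 1 to compound 3 (0.66 log units; beyond the scatter), also added carbon, but at another place, so it offers only loose guidance. On that guidance, a modest fall in this assay is expected, with an estimated step of a 1.6-fold lower number from compound 3 to compound 4 (0.21 log units; within the scatter). For compound 4 the estimated value is 20000 nM, with an expected range of 8000 nM to 50000 nM.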

Compound 4, half-maximal inhibitory concentration: 85300 nM
Compound 4: the middle estimate sits 4.3-fold (0.63 log units) below what was measured; the measured number lies above the stated range.
By their numbers in this assay, from the lowest: compound 3; then compounds 4 and 2 (each within the scatter of the next). At a limit, above all of these: compound 1.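

On a saturated chain carbon, three bonds along the chain from an amine nitrogen, replacing amino with pyrrolidin-1-yl gives, in this assay, a 2.7-fold higher number from compound 3 to compound 4 (0.42 log units; beyond the scatter). Added carbon therefore does not lower the number in every case: the earlier step from compound 1 to compound 3, which added carbon at another place, went the other way. Nothing given here explains this rise. On these data alone, it remains open whether the rise follows the ring itself or the loss of the amino hydrogens. An open-chain diethylamino group or a piperidin-1-yl ring at this place would help separate the two.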